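Formyl to fluoro on the phenyl arm of compound 3

The source may hold more compounds than are shown below. What is called first, only, known or untested is meant among the compounds shown, and "the series" means these compounds.

Compound 3 `O=Cc1ccc(-c2cn3ccnc3c(-c3ccc4ncn(C5CCCCC5)c4c3)n2)cc1` gives 16.5% in a functional assay on HL-60 cells (Homo sapiens) for inhibition, read by sulforhodamine B assay, with a stated time of 48 h, tested at 10 uM (on this read-out higher numbers stand for more inhibition at the one concentration tested (going by the name of the read-out) and lower numbers for less inhibition), the lowest of the three numbers; compound 1 `Brc1cn2ccnc2c(-c2ccc3ncn(C4CCCCC4)c3c2)n1` gives 18%, within the scatter of it, while compound 2 `c1ccc(-c2cn3ccnc3c(-c3ccc4ncn(C5CCCCC5)c4c3)n2)cc1` gives 67.1%, beyond the scatter. The step of a number 49.1 percentage points higher from compound 1 to compound 2 (beyond the scatter) was large, as was a number 50.6 percentage points lower from compound 2 to compound 3 (beyond the scatter); by contrast a number 1.5 percentage points lower from compound 1 to compound 3 (within the scatter) stayed within the scatter. Compound 4 `Fc1ccc(-c2cn3ccnc3c(-c3ccc4ncn(C5CCCCC5)c4c3)n2)cc1` differs from compound 3 by fluoro in place of formyl on an aromatic carbon. Within the data shown here, the step of a number 50.6 percentage points lower from compound 2 to compound 3 (beyond the scatter) bears most directly, and its reversal points to a gain of similar size; no measured step shows fluoro in place of hydrogen, so the upper end stays open. A large rise in this assay is therefore expected, a number 33.5 percentage points higher from compound 3 to compound 4 (beyond the scatter). Compound 4 is estimated at 50%, between 20% and 75%.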

Compound 4, a percentage reported as inhibition, at one concentration (the size of the read-out at that concentration, not a potency): 2.03%
For compound 4 the middle estimate is 48 percentage points above the measured one, outside the stated range (below it).
By their numbers in this assay, from the lowest: compound 4; then compounds 3 and 1 (each within the scatter of the next); then compound 2.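

In this assay, the small fluoro group does not keep the level of the unsubstituted phenyl (a number 65.1 percentage points lower from compound 2 to compound 4 (beyond the scatter)), so the loss at this place, para to a large group, is not confined to formyl. Fluoro also gives a lower number than formyl (a number 14.5 percentage points lower from compound 3 to compound 4 (beyond the scatter)), and the 4-fluorophenyl arm falls below even bromo (a number 16 percentage points lower from compound 1 to compound 4 (beyond the scatter)), so an aryl arm alone does not secure the gain seen with compound 2. No measurement offers an explanation for these drops. As far as these compounds go, whether an amine, a methoxy group or a carboxylic acid at this place would restore the number remains open.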